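The source may hold more compounds than are shown below. What is called first, only, known or untested is meant among the compounds shown, and "the series" means these compounds.

Compound 1, with the structure `Cc1cc(Oc2ccc(/C=N/NC(=S)Nc3ccc(F)cc3)cc2)ccc1Cl`, is a thiosemicarbazone bearing a fluorine on the outer aromatic ring. In a physicochemical assay for lipophilicity, in phosphate buffer, measured as octanol-water partition, with a stated time of 24 h (a higher number here means a more lipophilic compound, a lower number a more polar compound), compound 1 gives 6.07, the highest of the three measured numbers. Compound 2, `S=C(N/N=C/c1ccc(Oc2ccc(Cl)cc2)cc1)Nc1ccccc1`, gives 5.52 in this assay, and compound 3, `Cc1ccc(Oc2ccc(/C=N/NC(=S)Nc3ccc(F)cc3)cc2)cc1`, gives 5.48; both lie beyond the scatter below compound 1. Within the data shown here, the one step that changes a single place is a number 0.59 log units lower from compound 1 to compound 3 (beyond the scatter), where the oxygen-linked ring is trimmed; it concerns a different part of the molecule.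

Compound 4, `Cc1cc(Oc2ccc(/C=N/NC(=S)Nc3ccc(Br)cc3)cc2)ccc1Cl`, differs from compound 1 as follows: bromo in place of fluoro on an aromatic carbon. Bromo thus replaces fluoro on the aromatic carbon that bears the halogen. Among the measured compounds shown here, no measured pair shows this exchange, so the size of the step cannot be read off another pair; the measured step between compound 1 and compound 3 bears on it only by showing that single changes move the number by a modest amount. The estimate for compound 4 is therefore a step of a number 0.63 log units higher from compound 1 to compound 4 (beyond the scatter), upward, beyond the scatter. Compound 4 is expected to give 6.7 in this assay, with a likely range from 6.3 to 7.1.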

Compound 4, partition coefficient: 7.89
Estimate against measurement, compound 4: 1.19 log units below; measured number outside the range, above it.
By their numbers in this assay, from the lowest: compounds 3 and 2 (each within the scatter of the next); then compound 1; then compound 4.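

In this assay the exchange of fluoro for bromo gives a step of a number 1.82 log units higher from compound 1 to compound 4 (beyond the scatter) and so shows that this position, an aromatic carbon para to a large group, can move the partition number strongly. The change is small on paper: one heavy atom leaves, one heavy atom enters, and the count of hydrogen-bond donors, hydrogen-bond acceptors and net charge stays the same. Even so, this step is labelled large, whereas the earlier change on the oxygen-linked ring, a number 0.59 log units lower from compound 1 to compound 3 (beyond the scatter), is labelled modest, and nothing given here explains the size of the new step.

This single pair cannot show whether bromo in place of fluoro would give a step of similar size on the core of compound 3, where the oxygen-linked ring is 4-methylphenyl rather than 4-chloro-3-methylphenyl. Also open, as far as these compounds go, is where the number would fall with chloro, an amine or a carboxylic acid at this same position, and so whether the values follow any order across such groups.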